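Hexyl to Trifluoromethyl on a Shared Urea Core

The source may hold more compounds than are shown below. What is called first, only, known or untested is meant among the compounds shown, and "the series" means these compounds.

Three ureas share one core. Compound 1 `CC(C)c1ccc(NC(=O)N[C@@H](C)c2ccccc2)cc1` gives 98% in an ADME assay on the whole organism with Oryza sativa as the target, tested at 0.1 uM; on this read-out lower numbers stand for a stronger effect and higher numbers for a weaker effect at the one concentration tested; compound 2 `CCCCc1ccc(NC(=O)N[C@@H](C)c2ccccc2)cc1` gives 98%; compound 3 `CCCCCCc1ccc(NC(=O)N[C@@H](C)c2ccccc2)cc1` gives 99%. On the numbers shown compound 3 has the highest of the three, yet a number 1 percentage points higher from compound 1 to compound 3 (within the scatter) and a number 1 percentage points higher from compound 2 to compound 3 (within the scatter), so all three sit together. Compound 4 `C[C@H](NC(=O)Nc1ccc(C(F)(F)F)cc1)c1ccccc1` differs from compound 3 in one place: trifluoromethyl in place of hexyl on an aromatic carbon. Among the compounds with values here, the steps that bear on this change alter the same aromatic substituent: no change at the digits printed from compound 1 to compound 2 (within the scatter), a number 1 percentage points higher from compound 1 to compound 3 (within the scatter) and a number 1 percentage points higher from compound 2 to compound 3 (within the scatter), each within the scatter. Compound 4 is therefore expected to show no step beyond the scatter, a number 2 percentage points lower from compound 3 to compound 4 (within the scatter). Compound 4 is estimated at 97%, between 88% and 100%.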

Compound 4, a percentage reported as activity, at one concentration (the size of the read-out at that concentration, not a potency): 94%
Estimate against measurement, compound 4: 3 percentage points above; measured number inside the range.
By their numbers in this assay, from the lowest: compounds 4, 1, 2 and 3 (each within the scatter of the next).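

With trifluoromethyl in place of the carbon chains, this assay gives a number 5 percentage points lower from compound 3 to compound 4 (within the scatter) and a number 4 percentage points lower from compound 2 to compound 4 (within the scatter) and a number 4 percentage points lower from compound 1 to compound 4 (within the scatter). This extends the earlier picture from alkyl groups alone to a fluorine-bearing group: at this aromatic carbon, para to a large group, none of these exchanges produces a step beyond the scatter. No measurement is available that would explain these steps. As far as these compounds go, whether an amine or a carboxylic acid at this position would move the number beyond the scatter remains open.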